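Swapping an ether chain for a cyclic amine on the pyridine

This account rests on a few compounds, and the source may have more. Where it says the series, first, only, none or still open, it means among the compounds named here.

Measured compounds:
- compound 1, `C[S+]([O-])c1ccc(CSc2nc(-c3ccc(F)cc3)c(-c3ccncc3)[nH]2)cc1`, 380 nM
- compound 2, `CSc1nc(-c2ccc(F)cc2)c(-c2ccnc(OC(C)CCCC(C)C)c2)[nH]1`, "not determined" (no result reported)

The measured series is very short. In a functional assay on blood (Homo sapiens) for inhibition (on this read-out higher numbers stand for weaker inhibition and lower numbers for stronger inhibition), compound 1 gives 380 nM. In this assay, for the measured compounds named here, compound 2 gives "not determined" (no result reported), so it stands nowhere on the scale; the only measured anchor is compound 1, and no step from compound 1 to compound 2 can be drawn, since they differ in more than one place.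

Compound 3, `CSc1nc(-c2ccc(F)cc2)c(-c2ccnc(NC3CCCCC3C)c2)[nH]1`, differs from compound 2 at a single site: (2-methylcyclohexyl)amino in place of (1,5-dimethylhexyl)oxy on an aromatic carbon. The group that enters brings a hydrogen-bond donor where the leaving group had none, and a ring where the leaving group was an open chain.

Going by the values given here, because compound 2 carries no value, no step to compound 3 can be sized or given a direction; the only guide is compound 1 at 380 nM. On that basis compound 3 is expected to inhibit at about 120 nM, with a plausible range from 25 nM to 700 nM.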

Compound 3, half-maximal inhibitory concentration: 136 nM
Compound 3: middle estimate off by 1.1-fold (0.05 log units), on the low side, and the stated range covers the measured number.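

For the compounds shown here, compound 3 gives 136 nM in this assay, but compound 2 carries no number there, and no step between compound 2 and compound 3 can be read. Going by these compounds, what exchanging (1,5-dimethylhexyl)oxy for (2-methylcyclohexyl)amino does to inhibition stays open. No supporting data bear on this result.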